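A few compounds are considered here, and "the series" means these few. Any claim that something is new, unique, unknown or untested is made for them only; others in the source may bear on it.

Working notes on the series. In an ADME assay on MT4 cells (Homo sapiens) for cytotoxicity, read by MTT assay (on this read-out lower numbers stand for higher toxicity in this test and higher numbers for lower toxicity in this test), compound 1 `Cc1ccc(NC(=O)CSc2nncnc2-c2cccc3ccccc23)c(Br)c1` gives 166000 nM, the highest of the three numbers in hand. Compound 2 `Cc1ccc(NC(=O)CSc2nncnc2-c2ccccc2Cl)c(Br)c1` gives 45000 nM and compound 3 `CC(=O)c1ccc(NC(=O)CSc2nncnc2-c2ccccc2Cl)c(Br)c1` gives 34000 nM, both beyond the scatter below compound 1. Among the measured compounds shown here, the single step between measured compounds that differ in one place is a 1.3-fold lower number from compound 2 to compound 3 (0.12 log units; within the scatter), a change on the aromatic ring attached to the amide nitrogen that left the number essentially unmoved.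

Compound 4 `O=C(CSc1nncnc1-c1cccc2ccccc12)Nc1ccc(Cl)cc1Cl` differs from compound 1 by 2,4-dichlorophenyl in place of 2-bromo-4-methylphenyl on an amide-type nitrogen. For the measured compounds named here, no measured pair shows this exact exchange; the only step available on that ring, from compound 2 to compound 3, was within the scatter, so a small effect is the default reading, while the two chlorines in place of bromine and methyl leave room for some movement in either direction. The expectation for compound 4 in this assay is therefore a step of about a 1.4-fold lower number from compound 1 to compound 4 (0.14 log units; within the scatter), at most modest and not clearly beyond the scatter. Compound 4 is estimated at 120000 nM, within a range of 40000 nM to 300000 nM.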

Compound 4, half-maximal cytotoxic concentration: 254000 nM
The estimate for compound 4 lay 2.1-fold (0.33 log units) below the measured number; the measured number falls inside the stated range.
By their numbers in this assay, from the lowest: compounds 3 and 2 (each within the scatter of the next); then compounds 1 and 4 (each within the scatter of the next).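

The exchange of 2-bromo-4-methylphenyl for 2,4-dichlorophenyl on the amide-type nitrogen gives, in this assay, a 1.5-fold higher number from compound 1 to compound 4 (0.18 log units; within the scatter), so this position now shows a second exchange without a step beyond the scatter. The earlier step at this position, a 1.3-fold lower number from compound 2 to compound 3 (0.12 log units; within the scatter), came from a different pair, and the new step extends the same reading to the core of compound 1, with two ring substituents replaced at once. No measurement shown offers an explanation for this result.

The compounds shown leave open whether this position stays as flat with an amine or a carboxylic acid on the ring. They also leave open what the exchange of bromine for chlorine and the exchange of methyl for chlorine each contribute alone.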